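Replacing One Amide Group on Compound 2

The source may hold more compounds than are shown below. What is called first, only, known or untested is meant among the compounds shown, and "the series" means these compounds.

In a functional assay on MCF7 cells (Homo sapiens), read by MTT assay, with a stated time of 48 h (a lower number here means a stronger inhibitor, a higher number a weaker inhibitor), compound 1 (`CCn1c(C(=O)NCCN(C)C)ccc1C(CC)(CC)c1ccc(OCC(=O)C(C)(C)C)c(C)c1`) gives 520 nM and compound 2 (`CCOC(=O)CN(C)C(=O)c1ccc(C(CC)(CC)c2ccc(OCC(O)C(C)(C)C)c(C)c2)n1CC`) gives 9200 nM as the higher of the two numbers, a gap beyond the usual scatter. Compound 3 (`C#CCNC(=O)c1ccc(C(CC)(CC)c2ccc(OCC(O)C(C)(C)C)c(C)c2)n1CC`), not yet measured, differs from compound 2 in one place (propargylamino in place of ((ethoxycarbonyl)methyl)(methyl)amino on a carbonyl carbon): propargylamino in place of ((ethoxycarbonyl)methyl)(methyl)amino on a carbonyl carbon. For the measured compounds named here, no measured pair shows this change, which leaves the expectation uncertain. In this assay the expected change is an estimated 1.8-fold lower number from compound 2 to compound 3 (0.26 log units; within the scatter) and stays within the scatter, with a slightly lower number. In this assay compound 3 is expected at 5000 nM (estimated range 1500 nM to 17000 nM) once measured.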

Compound 3, half-maximal inhibitory concentration: > 50000 nM
Compound 3: no number, only a limit; the forecaster's own chance of this, stated with the estimate: 15%; middle value at least 10-fold (1.00 log units) from the limit.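

In this assay, the group on this carbonyl carbon matters: propargylamino in place of ((ethoxycarbonyl)methyl)(methyl)amino gives an at least 5.4-fold higher number from compound 2 to compound 3 (0.73 log units; beyond the scatter). Compound 1 and compound 2 differ in more than one place, so they could not show this. The true size of the step stays unknown because compound 3 stands at a limit: the limit of > 50000 nM in this assay, at which 1 of the 3 values shown sits.

The compounds shown do not separate the departure of the ester from the arrival of the triple bond or the amide hydrogen. Going by these compounds, how a propargyl(methyl)amino group on the same carbonyl carbon would read remains open.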